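Cytotoxicity Limits for Three Compounds and One Estimate

A few compounds are considered here, and "the series" means these few. Any claim that something is new, unique, unknown or untested is made for them only; others in the source may bear on it.

Measured so far:
Compound 1, `Cc1nc(C(=O)NCc2ccccc2)c(O)c(=O)n1C`: > 100000 nM
Compound 2, `Cn1c(Cc2ccccc2C(F)(F)F)nc(C(=O)CCc2ccccc2)c(O)c1=O`: > 100000 nM
Compound 3, `COc1c(C(=O)NCc2ccccc2)nc(Cc2ccccc2C(F)(F)F)n(C)c1=O`: > 100000 nM

Each of these values is a limit of the assay, not a measured number. In an ADME assay on HepG2 cells (Homo sapiens) for cytotoxicity, in the presence of a further agent that is not named here (on this read-out lower numbers stand for stronger inhibition and higher numbers for weaker inhibition), compound 2 gives > 100000 nM, which is such a limit. Its standing among the other two is therefore undecided, since (the limit of > 100000 nM in this assay, at which 3 of the 3 values shown sit). Compound 4, `Cn1c(Cc2ccccc2C(F)(F)F)nc(C(=O)NCC2CCCCC2)c(O)c1=O`, differs from compound 2 in one place: (cyclohexylmethyl)amino in place of phenethyl on a carbonyl carbon. Within the data shown here, no measured pair shows how a change of this kind moves the read-out here. The step that the limit leaves unreadable from compound 2 to compound 4 is expected to stay within the usual scatter, with compound 4 most likely reported as a limit again. Compound 4 is estimated at about 150000 nM, in a range from 50000 nM to 500000 nM.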

Compound 4, half-maximal inhibitory concentration: > 100000 nM
Compound 4: no number, only a limit (the forecaster's own chance of this, stated with the estimate: 85%); the middle value lies beyond the limit too.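

Among these compounds, no step from compound 2 to compound 4 can be read in this assay, since both results are limits and not numbers: the limit of > 100000 nM in this assay, at which 4 of the 4 values shown sit. The compounds shown leave open whether (cyclohexylmethyl)amino in place of phenethyl changes the read-out at all.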